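Adding a Fluorine to the Benzyl Arm of Compound 3

The source may report more compounds than this note shows. Statements on the series, on what has been measured and on what is new or still open speak of the compounds shown alone.

Three aminothiophene ketones bearing a naphthyl carbonyl have been tested in an assay on isolated protein with adenosine receptor A1 (Homo sapiens) as the target, tested at 10 uM; on this read-out higher numbers stand for more inhibition at the one concentration tested (going by the name of the read-out) and lower numbers for less inhibition. Compound 1 `Cc1sc(N)c(C(=O)c2ccc3ccccc3c2)c1C` gives 0%. Compound 2 `Nc1sc2c(c1C(=O)c1ccc3ccccc3c1)CCC2` gives 14.5%. Compound 3 `Nc1sc2c(c1C(=O)c1ccc3ccccc3c1)CCN(Cc1ccccc1)C2`, which carries a benzyl group on a ring nitrogen of its shared core, gives 2.5%. Among the three numbers compound 3 stands second highest; its reading and that of compound 1 lie within the usual scatter of each other, so the two cannot be told apart, while compound 2 sits beyond the scatter above it.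

Compound 4 `Nc1sc2c(c1C(=O)c1ccc3ccccc3c1)CCN(Cc1ccccc1F)C2` differs from compound 3 in one place: fluoro in place of hydrogen on an aromatic carbon. Among the measured compounds shown here, no pair of measured compounds differs by this change, so there is no measured step to lean on. The change adds a single fluorine and nothing else, and the expectation is for a step that stays within the scatter, in either direction. Compound 4 is therefore expected to give about 4%, in a range from 0% to 15%, which would mean an expected step of a number 1.5 percentage points higher from compound 3 to compound 4 (within the scatter) in this assay.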

Compound 4, a percentage reported as inhibition, at one concentration (the size of the read-out at that concentration, not a potency): 3%
Estimate against measurement, compound 4: 1 percentage points above, within the range that was stated.
By their numbers in this assay, from the lowest: compounds 1, 3 and 4 (each within the scatter of the next); then compound 2.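

Going from benzyl to 2-fluorobenzyl gives the first step between two measured compounds in this series, and in this assay that step is a number 0.5 percentage points higher from compound 3 to compound 4 (within the scatter) and so cannot be told from repeat-to-repeat variation. At this place on the benzyl arm, ortho to a large group, a single fluorine therefore leaves compound 4 indistinguishable from compound 3 on this read-out, which is a finding about this one substitution only. Nothing available here explains the result.

From the compounds shown here alone, what remains open is whether a larger group at the same place, such as methoxy, trifluoromethyl or an amine, would produce a step beyond the scatter. Going by these compounds, it is also open whether a carboxylic acid or a longer chain on that aromatic ring would shift the reading at all.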